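Hydroxy to carbamoyl on the amino-ester side chain

This account rests on a few compounds, and the source may have more. Where it says the series, first, only, none or still open, it means among the compounds named here.

Measured in a functional assay on the whole organism (Tail, strain ICR) with Mus musculus as the target, in the tail flick test, with a stated time of 120 min, at a dose of 25 umol/kg by the oral route; a lower number here means a weaker effect, a higher number a stronger effect of the compound at the dose given:
compound 1 `O=C(CN(c1ncnc2c1ncn2C1CCCCO1)C1CC1)N[C@@H](CO)C(=O)OCc1ccccc1` — 29.2%
compound 2 `CSCC[C@H](NC(=O)CN(c1nc(Cl)nc2[nH]cnc12)C1CC1)C(=O)OCc1ccccc1` — 31.6%
compound 3 `NC(=O)C[C@H](NC(=O)CN(c1nc(Cl)nc2[nH]cnc12)C1CC1)C(=O)OCc1ccccc1` — 15.1%

Compound 1 stands second highest of the three values; compound 2 lies within the scatter of it, while compound 3 sits lower, beyond the scatter. Compound 4 `NC(=O)C[C@H](NC(=O)CN(c1ncnc2c1ncn2C1CCCCO1)C1CC1)C(=O)OCc1ccccc1` differs from compound 1 by carbamoyl in place of hydroxy on a saturated chain carbon, two bonds along the chain from an amide-type nitrogen and a carbonyl carbon. Among the compounds with values here, one measured step bears on this: a number 16.5 percentage points lower from compound 2 to compound 3 (beyond the scatter), where carbamoyl entered at the same place from a different group and on a different core. Compound 4 is therefore expected to fall below compound 1, with a downward step of a number 12.2 percentage points lower from compound 1 to compound 4 (beyond the scatter) in this assay. The estimate for compound 4 is 17%, with a range of 6% to 30%.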

Compound 4, a percentage reported as activity, at one dose (the size of the read-out at that dose, not a potency): 29.2%
Beside the measured number, compound 4's estimate is 12.2 percentage points below it, within the range that was stated.
By their numbers in this assay, from the lowest: compound 3; then compounds 1, 4 and 2 (each within the scatter of the next).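

In this assay carbamoyl in place of hydroxy on the core of compound 1 gives no change at the digits printed from compound 1 to compound 4 (within the scatter) and so this position accepts carbamoylmethyl here without a loss beyond the scatter. The fall of a number 16.5 percentage points lower from compound 2 to compound 3 (beyond the scatter) therefore does not hold for every change to carbamoyl at this place, though that pair differs in both the group replaced and the core. Nothing available explains the difference between the two steps.

Still open, on these data alone, is whether a carboxylic acid or an amine at this place would match hydroxy and carbamoyl on the core of compound 1. As far as these compounds go, a longer chain ending in carbamoyl is equally open.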